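The source may hold more compounds than are shown below. What is called first, only, known or untested is meant among the compounds shown, and "the series" means these compounds.

Of the compounds shown here, two have been measured in a functional assay on K562/A02 cells (Homo sapiens) for antiproliferative activity, read by MTT assay; a lower number here means a stronger inhibitor, a higher number a weaker inhibitor. Compound 1, `Cc1ccccc1/C(=N/NC(=S)NCCCCCC(=O)NO)c1ccccc1`, gives 4220 nM, while compound 2, `COc1cccc(/C(C)=N/NC(=S)NCCCCCC(=O)NO)c1`, gives 1890 nM. Compound 1 therefore holds the higher of the two numbers, which makes it the weaker inhibitor of the pair by a margin beyond the usual scatter. Compound 3, `O=C(CCCCCNC(=S)N/N=C(\c1ccccc1)c1ccccc1[N+](=O)[O-])NO`, not yet measured, keeps the core of compound 1 with a single change: nitro in place of methyl on an aromatic carbon. In words, this is nitro in place of methyl on an aromatic carbon, ortho to a large group. Within the data shown here, no measured pair shows this change, so nothing in this assay calibrates it directly, and only a small shift toward a lower number, most likely none beyond the scatter, is expected. The expected step is a 1.4-fold lower number from compound 1 to compound 3 (0.15 log units; within the scatter). For compound 3 the estimated value is 3000 nM, with an expected range from 1200 nM to 8000 nM.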

Compound 3, half-maximal inhibitory concentration: 1310 nM
Compound 3: middle estimate off by 2.3-fold (0.36 log units), on the high side, within the range that was stated.
By their numbers in this assay, from the lowest: compounds 3 and 2 (each within the scatter of the next); then compound 1.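

In this assay, the exchange of 2-methylphenyl for 2-nitrophenyl gives a 3.2-fold lower number from compound 1 to compound 3 (0.51 log units; beyond the scatter), so this pair gives the first measured sign that a change on this aromatic carbon, ortho to a large group, can move the number beyond the scatter. Nitro, with its three heavy atoms and two hydrogen-bond acceptors, goes with the stronger inhibitor of the pair, although this rests on one step alone. Nothing available bears on what lies behind this step.

It remains open whether the lower number is particular to nitro, since the compounds shown carry neither an amine, a carboxylic acid nor a chlorine atom on this carbon. Among these compounds, they also leave open whether the same exchange would give a step of like size with a longer chain in place of the one in compound 1.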